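A few compounds are considered here, and "the series" means these few. Any claim that something is new, unique, unknown or untested is made for them only; others in the source may bear on it.

In a functional assay on A549 cells (Homo sapiens) for cytotoxicity, read by MTT assay, with a stated time of 48 h (on this read-out higher numbers stand for weaker inhibition and lower numbers for stronger inhibition), compound 1 `CCN(CC)c1ccc2cc(C(=O)c3ccc(N4CCN(C(=O)CN5CCNCC5)CC4)cc3)oc2c1` gives 320 nM.
In this assay compound 2 `CCN(CC)c1ccc2cc(C(=O)c3ccc(N4CCN(C(=O)CN5CCN(C(=O)CCl)CC5)CC4)cc3)oc2c1` gives 3060 nM.
In this assay compound 3 `CCN(CC)c1ccc2cc(C(=O)c3ccc(N4CCN(C(=O)CN5CCN(S(=O)(=O)C6CC6)CC5)CC4)cc3)oc2c1` gives 17300 nM.

Compound 3 stands highest of the three numbers in this assay: compound 2 is nearest, and compound 1 furthest, since a 54-fold higher number from compound 1 to compound 3 (1.73 log units; beyond the scatter) and a 5.7-fold higher number from compound 2 to compound 3 (0.75 log units; beyond the scatter). Both measured steps to compound 3 show that replacing hydrogen on the ring amine nitrogen with an acyl or sulfonyl group raises the number, and the cyclopropylsulfonyl group does so more than the (chloromethyl)carbonyl group.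

Compound 4 `CCN(CC)c1ccc2cc(C(=O)c3ccc(N4CCN(C(=O)CN5CCN(S(=O)(=O)c6ccc(OC(F)(F)F)cc6)CC5)CC4)cc3)oc2c1` differs from compound 3 in one place: 4-(trifluoromethoxy)phenyl in place of cyclopropyl on a sulfonyl sulfur. Going by the values given here, no measured step alters the group on this sulfonyl sulfur, so the size of the change has no direct precedent here. Among the compounds with values here, the steps that bear on it only show that the sulfonamide series already sits at the weak end of the series, and a larger aryl group on the same sulfur is not expected to move the number far in either direction. Compound 4 is therefore estimated at 15000 nM in this assay, with a range of 4000 nM to 60000 nM, which means an expected step of a 1.2-fold lower number from compound 3 to compound 4 (0.06 log units; within the scatter).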

Compound 4, half-maximal inhibitory concentration: > 40000 nM
Compound 4: only a limit was reported; the forecaster's own chance of this, stated with the estimate: 15%; at least 2.6-fold (0.42 log units) between middle value and limit.
By their numbers in this assay, from the lowest: compound 1; then compound 2; then compound 3. At a limit, above all of these: compound 4.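

Earlier compounds changed only what sat on the amine nitrogen in the ring, so they could not show whether the group carried by the sulfonyl sulfur matters on its own. With the sulfonamide kept in place, 4-(trifluoromethoxy)phenyl in place of cyclopropyl gives an at least 2.3-fold higher number from compound 3 to compound 4 (0.36 log units; beyond the scatter), so in this assay the number still responds to a change on this sulfur, and it moves further in the direction of weaker inhibition. The reading for compound 4 is a limit and not a number, so the step fixes only the least size of the change and leaves its full size unknown: the limit of > 40000 nM in this assay, at which 1 of the 4 values shown sits.

The compounds shown leave open whether the rise belongs to the aromatic ring itself or to the trifluoromethoxy group on it, a question that phenyl or 4-methoxyphenyl on the same sulfur would help to separate. They also leave open whether any group on this sulfur, such as methyl or an aryl ring carrying an amine or a carboxylic acid, could bring the number back towards that of compound 3 or lower.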